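A Ring Swap on Compound 1

The source may report more compounds than this note shows. Statements on the series, on what has been measured and on what is new or still open speak of the compounds shown alone.

In a functional assay on DU-145 cells (Homo sapiens) for inhibition, read by trypan blue exclusion, with a stated time of 96 h (a lower number here means a stronger inhibitor of growth, a higher number a weaker inhibitor of growth), compound 1 `O=C(O)c1ccc(C(=O)/C(=C\c2ccc(Br)c([N+](=O)[O-])c2)SCc2ccccc2Cl)cc1` gives 1000 nM. Going by the values given here, compound 3 `O=C(/C(=C\c1csc([N+](=O)[O-])c1)S(=O)(=O)c1ccc(Br)cc1)c1ccc(Br)cc1` stands level with it at 1000 nM, and these two share the lowest number of the three measured so far. Compound 2 `CSc1ccc(/C=C(\C(=O)c2ccc(Cl)cc2)S(=O)(=O)Cc2ccc(C)cc2)cc1` reads 10000 nM, a weaker result, beyond the usual scatter of compound 1. Compound 4 `O=C(O)c1ccc(C(=O)/C(=C\c2ccc(Br)c([N+](=O)[O-])c2)SCc2ccc(F)cc2)cc1` keeps the core of compound 1 and changes one group: 4-fluorophenyl in place of 2-chlorophenyl on a saturated chain carbon bound to a sulfur. Among the compounds with values here, no measured pair differs in one place only, so the data give no direct guide. In this assay, no step beyond the scatter is expected, in either direction. The estimated step is no change at the digits printed from compound 1 to compound 4 (within the scatter). For compound 4 the estimated value is 1000 nM, with an expected range from 300 nM to 4000 nM.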

Compound 4, concentration for 50% growth inhibition: 1000 nM
Beside the measured number, compound 4's estimate shows no gap at the digits printed, within the range that was stated.
By their numbers in this assay, from the lowest: compounds 1, 3 and 4 (each within the scatter of the next); then compound 2.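

In this assay, replacing 2-chlorophenyl with 4-fluorophenyl on a saturated chain carbon bound to a sulfur gives no change at the digits printed from compound 1 to compound 4 (within the scatter). Going by these compounds alone, this is the only single-place comparison here, and it shows that this place accepts this swap with no change beyond the scatter. The halogen and its ring position change together, so their separate contributions cannot be read, and no supporting data offer an explanation. Still open, from the compounds shown here alone, is what an unsubstituted phenyl would do at this place. An aminomethyl group or a longer alkyl chain in place of the ring also remains untested in the compounds shown here.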